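The compounds below may be only part of what the source reports. "The series", "measured", "known", "first", "only" and "open" are said of these compounds alone.

Measured in a functional assay on MCF7 cells (Homo sapiens) for antiproliferative activity, read by MTT assay, with a stated time of 48 h (on this read-out lower numbers stand for stronger inhibition and higher numbers for weaker inhibition), so far
- compound 1 `CN1CCN(CC(=O)Nc2ccc3ncnc(Nc4cccc(C(F)(F)F)c4)c3c2)CC1` gives > 100000 nM as a limit
- compound 2 `CN1CCN(CC(=O)Nc2ccc3ncnc(Nc4cccc(Cl)c4)c3c2)CC1` gives > 100000 nM as a limit
- compound 3 `O=C(CN1CCCCC1)Nc1ccc2ncnc(Nc3ccc(Cl)cc3)c2c1` gives > 100000 nM as a limit

Compound 3 gives no number, only a limit, and it stands with the other two compounds at the limit of > 100000 nM in this assay, at which 3 of the 3 values shown sit, in this series. Compound 4 `CN1CCN(CC(=O)Nc2ccc3ncnc(Nc4ccc(Cl)cc4)c3c2)CC1` differs from compound 3 in one group, with 4-methylpiperazin-1-yl in place of piperidin-1-yl on a saturated chain carbon bound to a carbonyl carbon.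

Going by the values given here, the only measured step, a step that the two limits leave unreadable from compound 1 to compound 2, is a change elsewhere in the molecule, so it offers no size to carry over. Compound 1 already carries 4-methylpiperazin-1-yl and shows > 100000 nM as a limit. Compound 2 carries it too and shows > 100000 nM as a limit.

No change beyond the usual scatter is therefore expected in this assay, in either direction, and another limit is the likeliest result. The expected step is a number no higher from compound 3 to compound 4 (the limit leaves the size open) as estimated here. The estimate for compound 4 is 100000 nM (30000 nM to 150000 nM).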

Compound 4, half-maximal inhibitory concentration: 15000 nM
For compound 4 the middle estimate is 6.7-fold (0.82 log units) above the measured one; the measured number lies below the stated range.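

In this assay, 4-methylpiperazin-1-yl in place of piperidin-1-yl on the saturated chain carbon gives an at least 6.6-fold lower number from compound 3 to compound 4 (0.82 log units; beyond the scatter), so a change at this place can bring a measurable number. That group does not do so alone, as the aryl group on the nitrogen also matters: 4-chlorophenyl in place of 3-chlorophenyl gives an at least 6.6-fold lower number from compound 2 to compound 4 (0.82 log units; beyond the scatter), and 4-chlorophenyl in place of 3-(trifluoromethyl)phenyl gives an at least 6.6-fold lower number from compound 1 to compound 4 (0.82 log units; beyond the scatter). Only compound 4 carries both 4-methylpiperazin-1-yl and 4-chlorophenyl, and the other compounds all stay at one assay limit: the limit of > 100000 nM in this assay, at which 3 of the 4 values shown sit.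

As far as these compounds go, the true size of all three steps stays open, as each starts from a limit and not from a number. The compounds shown also leave open whether morpholin-4-yl on the chain, or 4-bromophenyl on the nitrogen, would give a lower number than compound 4.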